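A few compounds are considered here, and "the series" means these few. Any claim that something is new, unique, unknown or untested is made for them only; others in the source may bear on it.

Measured so far:
compound 1 `C=C=C(Cc1ccccc1)CN(C)C`: 54 umol/kg
compound 2 `C=C=C(CN)Cc1ccc(Cl)cc1`: 7 umol/kg

Among the measured compounds shown here, in an assay on forebrain for inhibition of Monoamine oxidase (Mus musculus) (on this read-out higher numbers stand for an effect only at larger amounts of compound and lower numbers for an effect already at smaller amounts), compound 2 has the lower of the two numbers known so far, and its nearest neighbour, compound 1, sits far enough above it to lie beyond the usual scatter. Compound 3 `C=C=C(CN)Cc1ccc(OC)cc1` is not yet measured. It differs from compound 2 in one place: methoxy in place of chloro on an aromatic carbon. For the measured compounds named here, no measured pair shows this change, so the size of its effect in this assay is unknown. Compound 3 is expected to give 15 umol/kg, between 5 umol/kg and 45 umol/kg, an expected modest step toward a higher number, a 2.1-fold higher number from compound 2 to compound 3 (0.33 log units; beyond the scatter).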

Compound 3, dose for half-maximal effect: 16 umol/kg
Beside the measured number, compound 3's estimate is 1.1-fold (0.03 log units) below it; low and high end bracket the measured number.
By their numbers in this assay, from the lowest: compound 2; then compound 3; then compound 1.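

In this assay methoxy in place of chloro on an aromatic carbon gives a 2.3-fold higher number from compound 2 to compound 3 (0.36 log units; beyond the scatter) as a modest step, so the number does respond to the group at this place. Among the compounds shown here, this is the first step in the set that changes one place only, and it points toward a higher number. Nothing measured here accounts for the step.

A fluoro, a methyl or a nitrile at this place could show how far the trend extends. A dimethylamine on compound 2 would separate the amine's contribution from that of chloro.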